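Working notes: from compound 2 to compound 3

A few compounds are considered here, and "the series" means these few. Any claim that something is new, unique, unknown or untested is made for them only; others in the source may bear on it.

Measured so far in a functional assay on SH-SY5Y cells (Homo sapiens) for inhibition, read by sulforhodamine B assay (a higher number here means a weaker inhibitor, a lower number a stronger inhibitor), on the series:
- compound 1 (`COC(=O)CC/C(C)=C/Cc1c(OC)c(C)c2c(c1OCC#CCN1CCN(c3ccc(O)cc3)CC1)C(=O)OC2`): 46100 nM
- compound 2 (`COC(=O)CC/C(C)=C/Cc1c(OC)c(C)c2c(c1OCC#CCN1CCN(c3ccccc3OC)CC1)C(=O)OC2`): 43600 nM

Compound 2 has no rank of its own on these numbers, as its value and that of compound 1 lie within the scatter of each other. The next compound is compound 3 (`COC(=O)CC/C(C)=C/Cc1c(OC)c(C)c2c(c1OCC#CCN1CCN(C(=O)C3COc4ccccc4O3)CC1)C(=O)OC2`), not yet measured in this assay and otherwise unchanged from compound 2. It carries (2,3-dihydro-1,4-benzodioxin-2-yl)carbonyl in place of 2-methoxyphenyl on an amine nitrogen in a ring.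

Going by the values given here, only one measured step bears on this change. The step of a 1.1-fold lower number from compound 1 to compound 2 (0.02 log units; within the scatter) put 2-methoxyphenyl in place of 4-hydroxyphenyl on the same nitrogen and stayed within the scatter. Among the compounds with values here, no measured compound has a carbonyl on that nitrogen, so the data give no direction, and the evidence is thin. No shift beyond the scatter is therefore expected, with an estimated 1.1-fold lower number from compound 2 to compound 3 (0.04 log units; within the scatter) as the step. For compound 3 the estimated value is 40000 nM with 17000 nM to 95000 nM as the expected range.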

Compound 3, half-maximal inhibitory concentration: > 50000 nM
Compound 3: a limit, no number (the forecaster's own chance of this, stated with the estimate: 15%); middle value at least 1.2-fold (0.09 log units) from the limit.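

In this assay compound 3 gives > 50000 nM, a limit of the assay and not a number, and it is the only compound shown that stops there: the limit of > 50000 nM in this assay, at which 1 of the 3 values shown sits.

Only floors can be read from this limit: an at least 1.1-fold higher number from compound 2 to compound 3 (0.05 log units; that floor lies within the scatter), and an at least 1.0-fold higher number from compound 1 to compound 3 (0.03 log units; that floor lies within the scatter). Even so, this is the first evidence on a carbonyl-linked group on this amine nitrogen in a ring, as the two aryl groups shown are joined to it directly, and (2,3-dihydro-1,4-benzodioxin-2-yl)carbonyl gives no sign of a stronger inhibitor than those groups.

Going by these compounds, how far the true value of compound 3 lies past the limit stays open, and with it whether either step goes beyond the scatter. A benzoyl or acetyl group on the same nitrogen would help to separate the part played by the carbonyl from that of the ring system attached to it, and a benzyl group would test a carbon link in its place.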